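Fluorine on the sulfonamide aryl of a nicotinamide phosphoribosyltransferase inhibitor

A few compounds are considered here, and "the series" means these few. Any claim that something is new, unique, unknown or untested is made for them only; others in the source may bear on it.

The measured compounds:
compound 1, `O=C(/C=C/c1cccnc1)NCCCc1ccc(S(=O)(=O)Nc2ccccc2)cc1`, 5920 nM;
compound 2, `O=C(/C=C/c1cccnc1)NCCCc1cccc(S(=O)(=O)Nc2ccccc2)c1`, 235 nM;
compound 3, `O=C(/C=C/c1cccnc1)NCCCCCCc1cccc(S(=O)(=O)Nc2ccccc2)c1`, 10.5 nM.

All three share a cinnamide-like arm carrying a pyridine and an aryl sulfonamide joined through a chain. In an assay on isolated protein for inhibition of Nicotinamide phosphoribosyltransferase (Homo sapiens), read by WST assay, with stated times of 60 min, 5 min and 30 min, in the presence of a further agent that is not named here (a higher number here means a weaker inhibitor, a lower number a stronger inhibitor), compound 1 gives 5920 nM, compound 2 gives 235 nM, and compound 3 gives 10.5 nM. Compound 3 stands lowest of the three, and its distance to each of the other two lies beyond the usual scatter, so it is the strongest inhibitor among those measured.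

Compound 4, `O=C(/C=C/c1cccnc1)NCCCCCCc1cccc(S(=O)(=O)Nc2ccc(F)cc2)c1`, differs from compound 3 in one place: fluoro in place of hydrogen on an aromatic carbon. The change sits on the aromatic carbon para to a large group, on the phenyl of the sulfonamide, far from the chain whose length separates compound 2 from compound 3.

For such a small change no shift beyond the scatter is expected; the step of a 1.2-fold lower number from compound 3 to compound 4 (0.07 log units; within the scatter) is estimated as essentially flat. Compound 4 is therefore expected to give about 9 nM in this assay, with a range from 4 nM to 25 nM.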

Compound 4, half-maximal inhibitory concentration: 9.2 nM
The estimate for compound 4 lay 1.0-fold (0.01 log units) below the measured number; the range from low to high includes it.
By their numbers in this assay, from the lowest: compounds 4 and 3 (each within the scatter of the next); then compound 2; then compound 1.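

In this assay, placing fluoro on the aromatic carbon para to a large group gives a 1.1-fold lower number from compound 3 to compound 4 (0.06 log units; within the scatter), so this step leaves the inhibitor's standing unchanged. The earlier compounds shown here all carried an unsubstituted phenyl on the sulfonamide and so said nothing about this ring; the step now shows that phenyl to 4-fluorophenyl is accepted here with the six-carbon chain of compound 3 in place. Nothing available here bears on why the number holds.

From the compounds shown here alone, it remains open whether chloro, methoxy or trifluoromethyl on the same carbon would leave the number as flat, or whether fluoro on the other carbons of this phenyl would do so. Also open, going by these compounds, is whether the same fluoro step would hold on the shorter chain of compound 2.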